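The compounds below may be only part of what the source reports. "The series", "measured", "known", "first", "only" and "open" are said of these compounds alone.

Of the compounds shown here, three have been measured so far in an ADME assay on microsomes from liver (Homo sapiens) for metabolic stability, read by LC-MS, using NADPH, with stated times of 5 min and 30 min, tested at 1 uM; a lower number here means slower removal, a higher number faster removal of the compound. Compound 1 `CC(c1ccc2ncc(-c3cnn(C)c3)cc2c1)n1nnc2ncc(-c3ccc(C(N)=O)c(F)c3)nc21` gives 3 uL/min. Compound 2 `CC(c1cc2cc(-c3cnn(C)c3)cnc2cc1F)n1nnc2ncc(-c3ccc(C(N)=O)c(F)c3)nc21` gives 2 uL/min, and compound 3 `CNC(=O)c1ccc(-c2cnc3nnn(C(C)c4cc5cc(-c6cnn(C)c6)cnc5cc4F)c3n2)cc1F` gives 5 uL/min. Compound 2 thus sits at the low end of the three numbers: the step of a 1.5-fold lower number from compound 1 to compound 2 (0.18 log units; within the scatter) is small and within the scatter, so compound 1 and compound 2 cannot be told apart, whereas the step of a 2.5-fold higher number from compound 2 to compound 3 (0.40 log units; beyond the scatter) is beyond the scatter, so compound 3 is the only one clearly set apart from compound 2.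

Compound 4 `CC(c1c(F)cc2ncc(-c3cnn(C)c3)cc2c1F)n1nnc2ncc(-c3ccc(C(N)=O)c(F)c3)nc21` has not yet been measured. It differs from compound 2 by fluoro in place of hydrogen on an aromatic carbon. Among the compounds with values here, the one measured step that bears on this kind of change is a 1.5-fold lower number from compound 1 to compound 2 (0.18 log units; within the scatter), where fluoro in place of hydrogen on an aromatic carbon left the number within the scatter. The step of a 2.5-fold higher number from compound 2 to compound 3 (0.40 log units; beyond the scatter) concerns a methyl on an amide-type nitrogen and says nothing about a second fluoro on the shared core. On that basis the step of no change at the digits printed from compound 2 to compound 4 (within the scatter) is expected to stay within the scatter, with no clear direction. Compound 4 is therefore estimated to give 2 uL/min in this assay, with a likely range from 1 uL/min to 4 uL/min.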

Compound 4, intrinsic clearance in a liver preparation (reported as CLH), per the amount of preparation that the assay uses: 11 uL/min
Compound 4: middle estimate off by 5.5-fold (0.74 log units), on the low side; measured number outside the range, above it.
By their numbers in this assay, from the lowest: compounds 2, 1 and 3 (each within the scatter of the next, the first and the last beyond it); then compound 4.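

The same swap, fluoro in place of hydrogen on an aromatic carbon, does not act alike everywhere on the shared core of these compounds. In this assay, the earlier swap gave a 1.5-fold lower number from compound 1 to compound 2 (0.18 log units; within the scatter) and so showed no readable change, whereas this one, on a carbon ortho to a fused ring, ortho to a large group and meta to a fluoro group, gives a 5.5-fold higher number from compound 2 to compound 4 (0.74 log units; beyond the scatter) and therefore moves compound 4 to the top of the four numbers. The two steps show that the place of the swap matters for this read-out, although nothing measured here says what lies behind the difference at this position.

A single compound with fluoro at this place cannot show whether the higher number belongs to this one atom alone or to its pairing with the fluoro group already present, and a compound with only the new fluoro would separate those two readings. As far as these compounds go, it also remains open how a chloro or a methoxy group on the same carbon would read, and whether either would stay close to compound 2 or rise as compound 4 does.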